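Swapping an Aromatic Ring for a Short Chain

The source may report more compounds than this note shows. Statements on the series, on what has been measured and on what is new or still open speak of the compounds shown alone.

Of the compounds shown here, three sharing one core have been measured so far. Compound 1 `CC(C)CC(=O)N1CCc2cc(CNC(=O)c3ccco3)ccc21` was tested in an assay on HEK293 cells for inhibition of Indoleamine 2,3-dioxygenase 1 (Homo sapiens), tested at 10 uM (a higher number here means more inhibition at the concentration tested (going by the name of the read-out), a lower number less inhibition), and compound 1 gives 100%. Compound 2 `CC(C)C(=O)N1CCc2cc(CNC(=O)c3cccs3)ccc21`, which carries a thiophene-type amide instead, gives 100% in this assay, and compound 3 `CCC(=O)N1CCc2cc(CNC(=O)c3ccc(F)cc3)ccc21` gives 96%. Compound 1 stands level with compound 2 at the digits shown, and its number differs from that of compound 3 by an amount that lies within the usual scatter, so the three cannot be told apart.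

Compound 4 `CCCC(=O)NCc1ccc2c(c1)CCN2C(=O)CC(C)C` has not yet been measured. It differs from compound 1 in one place: propyl in place of furan-2-yl on a carbonyl carbon. The furan-2-yl group, a five-membered aromatic ring with one oxygen, is replaced by a propyl chain with no ring at all.

Among the measured compounds shown here, no measured pair here shows what replacing an aromatic ring with a chain does, so the step from compound 1 to compound 4 in this assay can only be guessed. Because compound 1 sits at 100%, there is no room to rise, so the expected step of a number 20 percentage points lower from compound 1 to compound 4 (beyond the scatter) is downward, with a wide spread. For compound 4 the estimate in this assay is 80%, ranging from 45% to 100%.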

Compound 4, a percentage reported as inhibition, at one concentration (the size of the read-out at that concentration, not a potency): 64%
Compound 4: middle estimate off by 16 percentage points, on the high side; low and high end bracket the measured number.
By their numbers in this assay, from the lowest: compound 4; then compounds 3, 1 and 2 (each within the scatter of the next).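

Among the compounds shown here, compound 1 and compound 4 are the first pair here that differ in one place only, and they show that the group on this carbonyl carbon matters: propyl in place of furan-2-yl gives a number 36 percentage points lower from compound 1 to compound 4 (beyond the scatter) in this assay. An aromatic ring at this place is still not required for inhibition, as compound 4 gives 64% at the single concentration tested, a reading of effect at that concentration rather than a potency. Nothing available here explains the drop.

This one step changes two things together, removing the ring and changing the number of heavy atoms, so the compounds shown cannot say which of the two counts. Cyclopentyl, a ring that is not aromatic, or a longer chain such as hexyl on the same carbonyl carbon would pull those two apart, while a phenyl or thiophene ring on the core of compound 1 would show whether other aromatic rings match furan-2-yl here.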